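The source may report more compounds than this note shows. Statements on the series, on what has been measured and on what is new or still open speak of the compounds shown alone.

In a functional assay on MCF7 cells (Homo sapiens) for inhibition, read by MTT assay (a lower number here means a stronger inhibitor, a higher number a weaker inhibitor), compound 1 `COc1cc2ncnc(Nc3ccc(NC(=O)c4ccccc4OC)cc3)c2cc1OC` gives > 100000 nM, which is a limit of the assay and not a number. Among the compounds with values here, compound 2 `COc1cc2ncnc(Nc3ccc(NC(=O)c4ccccc4Cl)cc3)c2cc1OC` gives 36000 nM, the only true number so far. The next compound to be tested is compound 3 `COc1cc2ncnc(Nc3ccc(NC(=O)c4ccc(Br)cc4)cc3)c2cc1OC`, and the change is 4-bromophenyl in place of 2-chlorophenyl on a carbonyl carbon; in words, 4-bromophenyl in place of 2-chlorophenyl on a carbonyl carbon. Within the data shown here, only one measured step bears on this, an at least 2.7-fold lower number from compound 1 to compound 2 (0.44 log units; beyond the scatter), where chloro replaced methoxy on an aromatic carbon. From the compounds shown here alone, it suggests that a swap on this ring can shift the reading, but 4-bromophenyl itself is untested, so it gives no clear direction. A change no larger than the scatter is therefore the best guess. The expected change is a 1.1-fold higher number from compound 2 to compound 3 (0.05 log units; within the scatter). Compound 3 is estimated at 40000 nM, with an expected range of 13000 nM to 100000 nM.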

Compound 3, half-maximal inhibitory concentration: 43000 nM
The estimate for compound 3 lay 1.1-fold (0.03 log units) below the measured number, within the range that was stated.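

In this assay, replacing 2-chlorophenyl with 4-bromophenyl on the carbonyl carbon gives a 1.2-fold higher number from compound 2 to compound 3 (0.08 log units; within the scatter), so this pair cannot be told apart even though the halogen and the group's name both change. Compared with 2-methoxyphenyl, 4-bromophenyl gives an at least 2.3-fold lower number from compound 1 to compound 3 (0.36 log units; beyond the scatter), so a second halogen-bearing group now stands apart from the methoxy-bearing one, and the earlier step no longer rests on chloro alone. The value of compound 1 is a limit and not a number, so the true size of both steps from it stays unknown: the limit of > 100000 nM in this assay, at which 1 of the 3 values shown sits.

The compounds shown cannot separate the change of halogen from the change of its place on the ring, as the two change together in this step. From the compounds shown here alone, how a plain phenyl, or a ring carrying an amine or a carboxylic acid, would read in this assay also remains open.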